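Swapping the aryl ether group ahead of a cytotoxicity read-out

This account rests on a few compounds, and the source may have more. Where it says the series, first, only, none or still open, it means among the compounds named here.

In an ADME assay on MRC5 cells (Homo sapiens) for cytotoxicity, read by fluorescence and resazurin assay, with a stated time of 3 days (on this read-out lower numbers stand for stronger inhibition and higher numbers for weaker inhibition), every number gathered so far is a limit of the assay rather than a measured value. Compound 1 `Cc1cn(C2CCN(Cc3cc(Oc4cccc(Cl)c4)ccn3)CC2)c(=O)[nH]c1=O` gives > 64000 nM, which is a limit. Compound 2 `Cc1cn(C2CCN(Cc3cccc(Oc4cccc(F)c4)c3)CC2)c(=O)[nH]c1=O` gives > 64000 nM, also a limit. Compound 3 `Cc1cn(C2CCN(Cc3cccc(Oc4ccccn4)c3)CC2)c(=O)[nH]c1=O` gives > 64000 nM, again a limit. Because of the limit of > 64000 nM in this assay, at which 3 of the 3 values shown sit, compound 3 stands where the other two stand, and nothing separates the three on these numbers. For the measured compounds named here, the one measured step that changes a single place, a step that the two limits leave unreadable from compound 2 to compound 3, cannot be given a size, since both of its ends are limits.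

Compound 4 `Cc1cn(C2CCN(Cc3cccc(Oc4ccc(Cl)c(C(F)(F)F)c4)c3)CC2)c(=O)[nH]c1=O` is the compound still to be measured. It differs from compound 3 by 4-chloro-3-(trifluoromethyl)phenyl in place of pyridin-2-yl on an oxygen on an aromatic ring. Going by the values given here, the only measured step that bears on this change is a step that the two limits leave unreadable from compound 2 to compound 3, which also swaps the group on an oxygen on an aromatic ring, and that step gives no readable size or direction. No shift beyond the scatter is therefore expected for the step of a number no higher from compound 3 to compound 4 (the limit leaves the size open), and the expectation is that compound 4 remains at the limit as well. The estimate for compound 4 in this assay is 64000 nM, with a range from 25000 nM to 150000 nM.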

Compound 4, half-maximal inhibitory concentration: 5280 nM
Estimate against measurement, compound 4: 12-fold (1.08 log units) above; the whole stated range lies above it.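

In this assay, the group on the oxygen on an aromatic ring turns out to be able to move the read-out: 4-chloro-3-(trifluoromethyl)phenyl in place of pyridin-2-yl gives an at least 12-fold lower number from compound 3 to compound 4 (1.08 log units; beyond the scatter), and the same group in place of 3-fluorophenyl gives an at least 12-fold lower number from compound 2 to compound 4 (1.08 log units; beyond the scatter). Compound 4 is the only compound here with a measured value rather than a limit, so the step between compound 2 and compound 3 still cannot be read, while this position is now shown to matter for the read-out. Both new steps are minimum sizes, and the true gaps may be larger, because each starts from a compound that gives no exact number: the limit of > 64000 nM in this assay, at which 3 of the 4 values shown sit.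

The compounds shown do not tell whether the chlorine, the trifluoromethyl or the two together go with the lower number, since the entering group brings both at once. A phenyl ring carrying only the chlorine or only the trifluoromethyl would separate the two, and a carboxylic acid or an amine on that ring would show how the read-out responds to a very different group.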